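The source may hold more compounds than are shown below. What is called first, only, known or untested is meant among the compounds shown, and "the series" means these compounds.

Of the compounds shown here, three share one core and have been measured in a functional assay on CFPAC-1 cells (Homo sapiens) for inhibition, read by MTT assay, with a stated time of 72 h; on this read-out lower numbers stand for stronger inhibition and higher numbers for weaker inhibition. Compound 1 `O=c1cc(Cn2cc(CCCCl)nn2)c2ccc(O)cc2o1` gives 75800 nM. Compound 2 `CCCCCc1ccc(-c2cn(Cc3cc(=O)oc4cc(O)ccc34)nn2)cc1` gives 50400 nM, and compound 3 `CCCC1CCC(c2ccc(-c3cn(Cc4cc(=O)oc5cc(O)ccc45)nn3)cc2)CC1` gives 52800 nM. The three numbers sit close together: the gaps between compound 1 and each of the other two fall within the usual scatter of this kind of measurement, so the data do not separate compound 1 from them. Among the measured compounds shown here, the one step between two measured compounds, a 1.0-fold higher number from compound 2 to compound 3 (0.02 log units; within the scatter), is also within the scatter.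

Compound 4 `O=c1cc(Cn2cc(CSC(=S)N3CCNCC3)nn2)c2ccc(O)cc2o1` has not yet been measured. It differs from compound 1 in one place: a group of 9 heavy atoms (5 carbon, 2 nitrogen, 2 sulfur; one six-membered non-aromatic ring with 2 hetero atoms) in place of a group of 3 heavy atoms (2 carbon, 1 chlorine; no ring), on a saturated chain carbon bound to an aromatic carbon. For the measured compounds named here, no measured step matches this change. Going by the values given here, the only step on record, a 1.0-fold higher number from compound 2 to compound 3 (0.02 log units; within the scatter), swaps one group for another at the far end of the molecule and tells nothing about the part of compound 1 that is replaced here. With nothing to lean on beyond the narrow spread of the three measured numbers, the expectation for compound 4 in this assay is no change beyond the scatter, which as a step means a 1.2-fold lower number from compound 1 to compound 4 (0.07 log units; within the scatter). The estimate for compound 4 is therefore 65000 nM, expected to lie between 20000 nM and 200000 nM.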

Compound 4, half-maximal inhibitory concentration: > 100000 nM
Compound 4: a limit, no number; the forecaster's own chance of this, stated with the estimate: 15%; middle value at least 1.5-fold (0.18 log units) from the limit.
By their numbers in this assay, from the lowest: compounds 2, 3 and 1 (each within the scatter of the next). At a limit, above all of these: compound 4.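

In this assay compound 4 gives no number, only a limit of the assay: the limit of > 100000 nM in this assay, at which 1 of the 4 values shown sits. Placing the larger group with its six-membered non-aromatic ring where 2-chloroethyl stood, on a saturated chain carbon bound to an aromatic carbon, amounts to an at least 1.3-fold higher number from compound 1 to compound 4 (0.12 log units; that floor lies within the scatter), so the smallest change the limit allows cannot be told apart from no change, and the data set no upper end to it. The earlier compounds shown here said nothing about this place, and the new result adds one firm point: this swap, which brings in sulfur, a ring, a hydrogen-bond donor and hydrogen-bond acceptors, gives no stronger inhibition than compound 1 shows.

As far as these compounds go, it remains open how much weaker compound 4 really is, and which part of the entering group, the ring or the sulfur-bearing link, accounts for the outcome. The compounds shown also leave unsettled whether a simple amine, a carboxylic acid or a longer chain at this place would move the number in either direction.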